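Changing the group on the carbonyl carbon

This account rests on a few compounds, and the source may have more. Where it says the series, first, only, none or still open, it means among the compounds named here.

Among the compounds with values here, in a functional assay on A2780 cells (Homo sapiens) for inhibition, read by sulforhodamine B assay, with a stated time of 72 h (on this read-out lower numbers stand for stronger inhibition and higher numbers for weaker inhibition), compound 3 (`O=C(NCc1ccc(S(=O)(=O)c2cccc(C(F)(F)F)c2)cc1)c1ccc2nccn2c1`) gives 2 nM, at the low end of the three numbers so far. Compound 2 (`O=C(NCc1ccc(S(=O)(=O)c2cccc(C(F)(F)F)c2)cc1)c1cc2ccncc2o1`) gives 3 nM, within the scatter of compound 3, while compound 1 (`O=C(NCc1ccc(S(=O)(=O)c2ccccc2)cc1)c1cc2ccncc2s1`) gives 14 nM, beyond the scatter from compound 3.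

Compound 4 (`O=C(NCc1ccc(S(=O)(=O)c2cccc(C(F)(F)F)c2)cc1)c1cc2ccncc2s1`) differs from compound 3 by a group of 9 heavy atoms (7 carbon, 1 nitrogen, 1 sulfur; one five-membered aromatic ring with 1 hetero atom, one six-membered aromatic ring with 1 hetero atom) in place of a group of 9 heavy atoms (7 carbon, 2 nitrogen; one five-membered aromatic ring with 2 hetero atoms, one six-membered aromatic ring with 1 hetero atom), on a carbonyl carbon. The amide-type nitrogen on that carbonyl carbon stays in place, and neither group carries a net charge.

Within the data shown here, only one measured step falls at this place: a 1.5-fold lower number from compound 2 to compound 3 (0.18 log units; within the scatter). That exchange of one group for another on the carbonyl carbon left the number within the scatter. Compound 1 differs from compound 2 and compound 3 in more than this one place, so its value gives no size for the present change. Among the measured compounds shown here, no measured single-place step involves the entering group, which leaves the expectation on thin ground and calls for a generous range.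

On the evidence of compound 3 and the step of a 1.5-fold lower number from compound 2 to compound 3 (0.18 log units; within the scatter), no change beyond the scatter is expected in this assay. The expected step is a 1.5-fold higher number from compound 3 to compound 4 (0.18 log units; within the scatter). Compound 4 is estimated at 3 nM, with an expected range of 1 nM to 8 nM.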

Compound 4, half-maximal inhibitory concentration: 1 nM
The estimate for compound 4 lay 3.0-fold (0.48 log units) above the measured number, within the range that was stated.
By their numbers in this assay, from the lowest: compounds 4, 3 and 2 (each within the scatter of the next, the first and the last beyond it); then compound 1.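

In this assay, this position on the carbonyl carbon now has a second and third reading. The exchange of the imidazole-free group of compound 3 is not the point here: the step (a 2.0-fold lower number from compound 3 to compound 4 (0.30 log units; within the scatter)) stays within the scatter, whereas the step (a 3.0-fold lower number from compound 2 to compound 4 (0.48 log units; beyond the scatter)) passes beyond it and is modest, so the sulfur-bearing group and the oxygen-bearing group, equal in heavy-atom count, can be told apart in this small set, even though compound 3 lies within the scatter of each. Compound 4 also ties compound 1 to the series through a single change, trifluoromethyl in place of hydrogen on an aromatic carbon, and that step (a 14-fold lower number from compound 1 to compound 4 (1.15 log units; beyond the scatter)) is large, the biggest single-place step among these four compounds.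

Still open, on these data alone, is how the number responds to an amine or a carboxylic acid on the group at the carbonyl carbon, and whether a chloro group or a longer chain in place of trifluoromethyl would keep the step seen from compound 1 to compound 4. Nothing available accounts for either the modest step or the large one.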